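Aryl sulfide to benzylamine on the shared diamino core

A few compounds are considered here, and "the series" means these few. Any claim that something is new, unique, unknown or untested is made for them only; others in the source may bear on it.

Compound 2 `Nc1cc(N)c2nc(-c3ccccc3)c(Sc3ccc(F)cc3)nc2c1` is the reference point. In a functional assay on HT-29 cells (Homo sapiens) for inhibition, read by sulforhodamine B assay, with a stated time of 48 h (a higher number here means a weaker inhibitor of growth, a lower number a stronger inhibitor of growth), compound 2 gives 45700 nM, the highest of the two numbers in hand. Compound 3 `COc1cc(CNc2nc3cc(N)cc(N)c3nc2-c2ccccc2)cc(OC)c1OC`, which carries a benzylamino-type group rather than a sulfanyl one, gives 19500 nM, a gap beyond the usual scatter. For compound 1 `CCOC(=O)[C@H](CCC(=O)O)NC(=O)c1ccc(Sc2nc3cc(N)cc(N)c3nc2-c2ccccc2)cc1` the this assay reading is only a limit, < 100000 nM, and not a number.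

Compound 4 `Nc1cc(N)c2nc(-c3ccccc3)c(NCc3ccc(F)cc3)nc2c1` differs from compound 2 in a single place: (4-fluorobenzyl)amino in place of (4-fluorophenyl)sulfanyl on an aromatic carbon. Within the data shown here, no measured pair shows this exact exchange. Since compound 3 with its amino-linked benzyl group gives 19500 nM, a modest gain is expected; the step of a 1.8-fold lower number from compound 2 to compound 4 (0.26 log units; within the scatter) is estimated as a decrease of moderate size, just beyond the scatter. For compound 4 the expected value is 25000 nM, within 8000 nM to 80000 nM.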

Compound 4, concentration for total growth inhibition: 12600 nM
Estimate against measurement, compound 4: 2.0-fold (0.30 log units) above; the range from low to high includes it.
By their numbers in this assay, from the lowest: compounds 4 and 3 (each within the scatter of the next); then compound 2.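

In this assay, (4-fluorobenzyl)amino in place of (4-fluorophenyl)sulfanyl on the aromatic carbon next to the ring nitrogen gives a 3.6-fold lower number from compound 2 to compound 4 (0.56 log units; beyond the scatter). This single-place step shows that the sulfur link is not needed at this position and that the amino-linked benzyl group gives the lower number with the 4-fluoro ring present in both. Nothing measured here bears on the cause of this step.

The exchange alters the linking atom and adds a carbon together, so the two changes remain unseparated. (4-Fluorophenyl)amino and (4-fluorobenzyl)sulfanyl at this position would tell them apart.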